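Swapping Fluorine for Chlorine on the Aryl Ring

The source may hold more compounds than are shown below. What is called first, only, known or untested is meant among the compounds shown, and "the series" means these compounds.

Measured compounds:
compound 1 `CCC(C(=O)N1CCN(c2cccc(F)c2)CC1)N1C(=O)CCC1=O`: 100%
compound 2 `CCC(C(=O)N1CCN(c2ccc(F)cc2)CC1)N1C(=O)CCC1=O`: 25%

In a functional assay on the whole organism (strain Swiss) with Mus musculus as the target, in the maximal electroshock model, with a stated time of 0.5 h, at a dose of 300 mg/kg by the intraperitoneal route (a lower number here means a weaker effect, a higher number a stronger effect of the compound at the dose given), compound 1 gives 100%, while compound 2 gives 25%, the lower of the two numbers. Among the compounds with values here, the only measured step, a number 75 percentage points lower from compound 1 to compound 2 (beyond the scatter), concerns where the fluorine sits on the ring, not which halogen is present. Compound 3 `CCC(C(=O)N1CCN(c2ccc(Cl)cc2)CC1)N1C(=O)CCC1=O` differs from compound 2 by chloro in place of fluoro on an aromatic carbon. Within the data shown here, no measured step exchanges one halogen for another, so the data give no guide to the size or direction of this change. Compound 3 is therefore expected to show a step of a number 10 percentage points higher from compound 2 to compound 3 (within the scatter), an estimate of 35% with a range from 5% to 80%.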

Compound 3, a percentage reported as activity, at one dose (the size of the read-out at that dose, not a potency): 0%
For compound 3 the middle estimate is 35 percentage points above the measured one, and the stated range ends above it.
By their numbers in this assay, from the lowest: compound 3; then compound 2; then compound 1.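

At this position, the halogen itself matters as well as where it sits: in this assay, chloro in place of fluoro on an aromatic carbon, para to a large group, gives a number 25 percentage points lower from compound 2 to compound 3 (beyond the scatter). The change from 3-fluorophenyl to 4-chlorophenyl gives a number 100 percentage points lower from compound 1 to compound 3 (beyond the scatter), which spans the full gap among these compounds. No evidence here accounts for the effect of this exchange. The compounds shown leave open how a 3-chlorophenyl group would behave. They also leave open how bromo or methoxy would compare with fluoro and chloro at this position.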